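Title: From a decyl chain to a benzyl group on the core

The source may report more compounds than this note shows. Statements on the series, on what has been measured and on what is new or still open speak of the compounds shown alone.

Measured so far:
compound 1 `C=CCN1C(=C(C(=O)OCC)C(=O)OCC)N([C@H]2OC(CO)[C@H]3OC(C)(C)O[C@H]32)c2cc(N)nc(O)c21`, 0%
compound 2 `CCCCCCCCCCn1c(=O)n(C2OC(CO)[C@@H](O)[C@H]2O)c2nc(N)nc(O)c21`, 0%

In a functional assay on the whole organism (B cells) with Mus musculus as the target (a higher number here means a larger maximal response, a lower number a smaller maximal response), compound 1 gives 0%, and compound 2 gives 0%, so compound 2 stands level with compound 1. Compound 3 `Nc1nc(O)c2c(n1)n(C1OC(CO)[C@@H](O)[C@H]1O)c(=O)n2Cc1ccccc1` has not yet been measured. It differs from compound 2 by phenyl in place of nonyl on a saturated chain carbon bound to an aromatic nitrogen. Going by the values given here, no step between two measured compounds is known, so the effect of this change can only be guessed. Since compound 2 gives 0%, the expected step from compound 2 to compound 3 is a number 5 percentage points higher from compound 2 to compound 3 (within the scatter), none beyond the scatter. For compound 3 the estimated value is 5%, ranging from 0% to 30%.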

Compound 3, largest response reached (reported as maximal response), in percent of the reference or control that the assay uses: 110%
Estimate against measurement, compound 3: 105 percentage points below; measured number outside the range, above it.
By their numbers in this assay, from the lowest: compounds 1 and 2 (each within the scatter of the next); then compound 3.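

In this assay, putting phenyl in place of nonyl on a saturated chain carbon bound to an aromatic nitrogen gives a number 110 percentage points higher from compound 2 to compound 3 (beyond the scatter) on an otherwise unchanged structure. This shows that the group at this position can decide whether the compound gives a response at all, and that a decyl chain and a benzyl group are far from interchangeable here. No measurement on hand gives a reason for this step. The compounds shown leave open whether the aromatic ring or the shorter reach matters, which a cyclohexylmethyl group or a butyl chain at this position could help separate.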